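The compounds below may be only part of what the source reports. "The series", "measured", "known", "first", "only" and "open" are said of these compounds alone.

Three compounds share one core and differ in the group on an aromatic carbon of that core. In an assay (Rattus norvegicus) for inhibition of Fatty-acid amide hydrolase 1 (Homo sapiens) (a higher number here means a weaker inhibitor, a lower number a stronger inhibitor), compound 1 `O=C(CCCCCCc1ccccc1)c1ncc(-c2ccc([N+](=O)[O-])cc2)o1` gives 50 nM. Compound 2 `Nc1ccc(-c2cnc(C(=O)CCCCCCc3ccccc3)o2)cc1` gives 90 nM in this assay, the highest of the three numbers, and compound 3 `NS(=O)(=O)c1ccc(-c2cnc(C(=O)CCCCCCc3ccccc3)o2)cc1` gives 10 nM in this assay. The measured steps are a 1.8-fold higher number from compound 1 to compound 2 (0.26 log units; within the scatter), a 5.0-fold lower number from compound 1 to compound 3 (0.70 log units; beyond the scatter) and a 9.0-fold lower number from compound 2 to compound 3 (0.95 log units; beyond the scatter). Compound 4 `Cc1cccnc1-c1cnc(C(=O)CCCCCCc2ccccc2)o1` differs from compound 2 by 3-methylpyridin-2-yl in place of 4-aminophenyl on an aromatic carbon. For the measured compounds named here, no measured step exchanges the ring itself; the steps only vary a substituent on the ring that leaves, so nothing in them points to a step beyond the scatter in this assay for this change. Compound 4 is therefore estimated at 150 nM, within 40 nM to 600 nM, an expected 1.7-fold higher number from compound 2 to compound 4 (0.22 log units; within the scatter).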

Compound 4, inhibition constant: 15 nM
Compound 4: middle estimate off by 10-fold (1.00 log units), on the high side, and the stated range ends above it.
By their numbers in this assay, from the lowest: compounds 3 and 4 (each within the scatter of the next); then compounds 1 and 2 (each within the scatter of the next).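

The earlier compounds shown here varied only a substituent on the phenyl ring, whereas here the ring itself is exchanged on the aromatic carbon next to the ring oxygen. In this assay, 3-methylpyridin-2-yl in place of 4-aminophenyl gives a 6.0-fold lower number from compound 2 to compound 4 (0.78 log units; beyond the scatter), and in place of 4-nitrophenyl it gives a 3.3-fold lower number from compound 1 to compound 4 (0.52 log units; beyond the scatter), so this position accepts a change of the whole ring, with both steps beyond the scatter. Nothing available bears on the origin of these steps. Going by these compounds, whether the ring nitrogen or the methyl matters more stays open; an unsubstituted pyridine ring or a methylphenyl ring would separate the two.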